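Swapping the aryl group on the ring nitrogen

This account rests on a few compounds, and the source may have more. Where it says the series, first, only, none or still open, it means among the compounds named here.

Measured compounds in a functional assay on A549 cells (Homo sapiens) for inhibition, read by MTT assay, with a stated time of 72 h; a lower number here means a stronger inhibitor, a higher number a weaker inhibitor:
compound 1, `COc1cc2c(Oc3ccc(NC(=O)c4nn(-c5ccccc5OC(F)(F)F)c(=O)cc4C)cc3F)ccnc2cc1OCCCN1CCC(C)CC1`: 90 nM
compound 2, `COc1ccc(-n2nc(C(=O)Nc3ccc(Oc4ccnc5cc(OCCCN6CCC(C)CC6)c(OC)cc45)c(F)c3)c(C)cc2=O)cc1`: 1100 nM

Within the data shown here, compound 2 stands at the higher of the two measured numbers, and its only neighbour is compound 1, which gave the lower number. Among the measured compounds shown here, the one measured step, a 12-fold higher number from compound 1 to compound 2 (1.09 log units; beyond the scatter), is the sole guide to how the aryl group on the aromatic nitrogen affects the read-out in this assay.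

Compound 3, `COc1cc2c(Oc3ccc(NC(=O)c4nn(-c5ccc(Cl)cc5Cl)c(=O)cc4C)cc3F)ccnc2cc1OCCCN1CCC(C)CC1`, differs from compound 2 by 2,4-dichlorophenyl in place of 4-methoxyphenyl on an aromatic nitrogen. For the measured compounds named here, no measured pair shows this exact exchange, so the step from compound 2 to compound 1 is the only one that bears on it, and it was large. Since compound 3, like compound 1, carries a substituent ortho to the point of attachment rather than the 4-methoxyphenyl of compound 2, the expectation is that the number falls back toward that of compound 1, giving an expected step of a 7.3-fold lower number from compound 2 to compound 3 (0.87 log units; beyond the scatter). Compound 3 is therefore estimated at 150 nM in this assay, with a range from 45 nM to 600 nM.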

Compound 3, half-maximal inhibitory concentration: 200 nM
Compound 3: middle estimate off by 1.3-fold (0.12 log units), on the low side; the measured number falls inside the stated range.
By their numbers in this assay, from the lowest: compound 1; then compound 3; then compound 2.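

In this assay, the step of a 5.5-fold lower number from compound 2 to compound 3 (0.74 log units; beyond the scatter) shows that the low number at this ring nitrogen is not unique to 2-(trifluoromethoxy)phenyl, since 2,4-dichlorophenyl also recovers much of the gap left by 4-methoxyphenyl. The step of a 2.2-fold higher number from compound 1 to compound 3 (0.35 log units; beyond the scatter) shows that the two groups are still not equivalent, with 2-(trifluoromethoxy)phenyl giving the lowest number of the three compounds and the difference lying beyond the usual scatter. No evidence is available to explain why the three aryl groups fall in this order.

2,4-dichlorophenyl carries two chlorine atoms. The compounds shown do not reveal which chlorine accounts for the step, and neither 2-chlorophenyl nor 4-chlorophenyl appears among them. They also leave open how the unsubstituted phenyl group, a pyridyl ring or a saturated cyclohexyl group would read at this ring nitrogen.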